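This account rests on a few compounds, and the source may have more. Where it says the series, first, only, none or still open, it means among the compounds named here.

Compound 1 `COc1cc(-c2ccc(CO[C@H]3C[C@@H](N=C=S)C3)c(F)c2)ccc1F` is one of two compounds with a number in an assay on isolated protein for inhibition of N-acylethanolamine-hydrolyzing acid amidase (Homo sapiens), read by fluorescence, with a stated time of 90 min (on this read-out higher numbers stand for weaker inhibition and lower numbers for stronger inhibition), and in this assay compound 1 gives 155 nM. The other is compound 2 `COc1ccc(C23CC(C(=O)N[C@H]4C[C@@H](N=C=S)C4)(C2)C3)cc1`, which in this assay gives 128 nM. The two numbers sit within the scatter of each other, so the data offer no grounds to separate compound 1 from compound 2.

The next compound, compound 3 `COc1ccc(-c2ccc(CO[C@H]3C[C@@H](N=C=S)C3)c(F)c2)cc1OC`, differs from compound 1 in one place: methoxy in place of fluoro on an aromatic carbon. Within the data shown here, no measured pair shows this exchange, so nothing among the measured compounds sets a size or a direction for it. Compound 1 is therefore the only anchor, and the step from compound 1 to compound 3 is expected to be a 1.0-fold higher number from compound 1 to compound 3 (0.01 log units; within the scatter), that is, none beyond the scatter. Compound 3 is accordingly estimated at 160 nM in this assay, with a range from 60 nM to 450 nM.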

Compound 3, half-maximal inhibitory concentration: 58.9 nM
Beside the measured number, compound 3's estimate is 2.7-fold (0.43 log units) above it, and the stated range ends above it.
By their numbers in this assay, from the lowest: compound 3; then compounds 2 and 1 (each within the scatter of the next).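

Placing methoxy where fluoro stood on this aromatic carbon, ortho to a methoxy group and para to a large group, gives the first change in this assay that can be read as a step: a 2.6-fold lower number from compound 1 to compound 3 (0.42 log units; beyond the scatter) is a modest move towards stronger inhibition. The earlier compounds shown here differed in more than one place and could not isolate this position. It now appears that the number here responds to the group at this carbon, and that methoxy, with 2 heavy atoms and 1 hydrogen-bond acceptor, is accepted in place of fluoro. Nothing shown here explains the step.

From the compounds shown here alone, whether a hydroxyl, an ethoxy or an amine at this carbon would go further in the same direction remains open. So does whether the same exchange would give a step of similar size on a different core.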